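Shortening the side chain on the shared core

The source may hold more compounds than are shown below. What is called first, only, known or untested is meant among the compounds shown, and "the series" means these compounds.

Measured so far in an ADME assay on MCF7-DOX cells (Homo sapiens) for cytotoxicity, read by MTT assay, with a stated time of 48 h; on this read-out higher numbers stand for weaker inhibition and lower numbers for stronger inhibition:
Compound 1 `CCCc1c(OC)cc(OC)c(C(=O)/C=C/c2cccc(N3CCNCC3)c2)c1O`: > 100000 nM (a limit, not a number)
Compound 2 `COc1cc(OC)c(C(=O)/C=C/c2cccc(N3CCNCC3)c2)c(O)c1CC=C(C)C`: 99900 nM

In this assay, going by the values given here, compound 2 gives 99900 nM, the only actual number so far. Compound 1 is reported only as a limit, > 100000 nM. The position of the series is therefore framed by the limit of > 100000 nM in this assay, at which 1 of the 2 values shown sits.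

The next compound is compound 3 `CCc1c(OC)cc(OC)c(C(=O)/C=C/c2cccc(N3CCNCC3)c2)c1O`, not yet measured. The change is methyl in place of 2-methylprop-1-en-1-yl on a saturated chain carbon bound to an aromatic carbon. Cut one bond further out, this reads 3-methylbut-2-en-1-yl to ethyl.

Among the compounds with values here, one measured step bears on this change: a number no higher from compound 1 to compound 2 (the limit leaves the size open). As far as these compounds go, it concerns the same place on the shared core, but its size stays open, so it gives direction only and no magnitude. Going the other way, from the larger group to a smaller one, compound 3 is expected to stay in the weak range of compound 1, with any shift toward higher numbers. The expected step is a 1.3-fold higher number from compound 2 to compound 3 (0.11 log units; within the scatter), and a result reported only as a limit would be unsurprising. For compound 3 the estimated value is 130000 nM, with an expected range of 60000 nM to 300000 nM.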

Compound 3, half-maximal inhibitory concentration: > 100000 nM
Compound 3: only a limit was reported; the forecaster's own chance of this, stated with the estimate: 65%; the middle value lies beyond the limit too.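

In this assay, methyl in place of 2-methylprop-1-en-1-yl on a saturated chain carbon bound to an aromatic carbon, which cut one bond further out reads 3-methylbut-2-en-1-yl to ethyl, gives a number no lower from compound 2 to compound 3 (the limit leaves the size open), so this second change at the same place again gives a direction and no size. Compound 3 is reported only as a limit, > 100000 nM. Going by these compounds alone, the step between compound 1 and compound 3 cannot be read, so the two shorter chains cannot be ordered, and compound 2 remains the only compound with an actual number, while the series now sits mostly at a limit: the limit of > 100000 nM in this assay, at which 2 of the 3 values shown sit.

As far as these compounds go, whether a longer saturated chain, an amine or a carboxylic acid at this place would give a number clearly lower than that of compound 2 stays open. With no value shown that stands clear of the limit, the compounds give no size for any change at this position in this assay.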